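Swapping the phenoxy substituent at the ether end of the series

This account rests on a few compounds, and the source may have more. Where it says the series, first, only, none or still open, it means among the compounds named here.

Compound 1, `Cc1nn(Cc2ccc(C(N)=O)cc2)c(C)c1NC(=O)c1ccc(COc2ccccc2)cc1`, in a functional assay on MIA PaCa-2 cells (Homo sapiens) for antiproliferative activity, read by MTT assay, with a stated time of 72 h (on this read-out lower numbers stand for an effect already at smaller amounts and higher numbers for an effect only at larger amounts of compound), gives only a limit, > 100000 nM.
Compound 2, `Cc1nn(Cc2cccc(C(=O)N(C)C)c2)c(C)c1NC(=O)c1ccc(COc2ccccc2)cc1`, in this assay gives 6400 nM.
Compound 3, `CNC(=O)c1cccc(Cn2nc(C)c(NC(=O)c3ccc(COc4ccccc4C)cc3)c2C)c1`, in this assay gives 2100 nM.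

Compound 3 stands at the lowest of the two numbers; compound 2 is its nearest neighbour and sits at a higher number, beyond the scatter, while compound 1 contributes only a limit, (the limit of > 100000 nM in this assay, at which 1 of the 3 values shown sits).

Compound 4, `CNC(=O)c1cccc(Cn2nc(C)c(NC(=O)c3ccc(COc4ccc(Cl)cc4)cc3)c2C)c1`, differs from compound 3 by 4-chlorophenyl in place of 2-methylphenyl on an oxygen on a saturated carbon. Going by the values given here, the one measured step, an at least 15-fold lower number from compound 1 to compound 2 (1.19 log units; beyond the scatter), concerns the group on the saturated chain carbon bound to the aromatic nitrogen, not the phenoxy end, and so does not bear on this change. Compound 2 and compound 3 differ at both ends at once, so their two values give no isolated reading of the phenoxy substituent. Among the compounds with values here, with no step touching this position, the change from compound 3 to compound 4 is expected to stay within the scatter, a 1.2-fold higher number from compound 3 to compound 4 (0.08 log units; within the scatter). Compound 4 is therefore estimated at 2500 nM, in the range from 800 nM to 8000 nM.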

Compound 4, half-maximal effective concentration: 4200 nM
Estimate against measurement, compound 4: 1.7-fold (0.23 log units) below, and the stated range covers the measured number.
By their numbers in this assay, from the lowest: compounds 3, 4 and 2 (each within the scatter of the next, the first and the last beyond it). At a limit, above all of these: compound 1.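

Going by these compounds alone, this is the first reading of the phenoxy end with the rest of the molecule held constant: in this assay, the exchange gives a 2.0-fold higher number from compound 3 to compound 4 (0.30 log units; within the scatter), so the two compounds cannot be told apart at this position. The exchange swaps a 2-methylphenyl for a 4-chlorophenyl of the same heavy-atom count, and this one step shows that the read-out tolerates a change of both the substituent and its place on the ring. Nothing in the data at hand explains this step.

Because both the substituent and its place change at once, the effect of each stays unresolved; 4-methylphenyl or 2-chlorophenyl on the same oxygen would separate them. Also open, going by these compounds, is how an amine or a carboxylic acid on this ring would read, in place of the methyl or the chlorine.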